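A Bromine on the Benzyl Group: Expected Tolerance

This account rests on a few compounds, and the source may have more. Where it says the series, first, only, none or still open, it means among the compounds named here.

Compound 1, `CCCN1C(=O)/C(=C\C(=O)C[C@@H]2O[C@H](COC(C)=O)[C@@H](OC(C)=O)[C@H](OC(C)=O)[C@H]2OC(C)=O)c2ccccc21`: 125000 nM
Compound 2, `CC(=O)OC[C@H]1O[C@@H](CC(=O)/C=C2\C(=O)N(Cc3ccccc3)c3ccccc32)[C@H](OC(C)=O)[C@@H](OC(C)=O)[C@@H]1OC(C)=O`: 71200 nM

Both numbers come from an ADME assay on Vero cells (Chlorocebus sabaeus) for cytotoxicity, read by resazurin assay, with a stated time of 72 h; a higher number here means that more compound is tolerated, a lower number that less compound is tolerated. Of the two, that of compound 2 is the smaller, but the step of a 1.8-fold lower number from compound 1 to compound 2 (0.24 log units; within the scatter) lies within the scatter, so the two compounds cannot be told apart on these data.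

Compound 3, `CC(=O)OC[C@H]1O[C@@H](CC(=O)/C=C2\C(=O)N(Cc3ccc(Br)cc3)c3ccccc32)[C@H](OC(C)=O)[C@@H](OC(C)=O)[C@@H]1OC(C)=O`, differs from compound 2 by bromo in place of hydrogen on an aromatic carbon. Among the measured compounds shown here, only one measured step bears on this change, the one from compound 1 to compound 2, which altered the group on the amide-type nitrogen and stayed within the scatter. For the measured compounds named here, no measured compound shows what a bromo group on this ring does. I therefore expect a step of a 1.3-fold lower number from compound 2 to compound 3 (0.11 log units; within the scatter) that stays within the scatter. Compound 3 is expected to give about 55000 nM in this assay, with a range from 25000 nM to 110000 nM.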

Compound 3, half-maximal cytotoxic concentration: 76500 nM
Estimate against measurement, compound 3: 1.4-fold (0.14 log units) below; the range from low to high includes it.
By their numbers in this assay, from the lowest: compounds 2, 3 and 1 (each within the scatter of the next).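

In this assay, the bromo group on the aromatic ring of the benzyl group gives a 1.1-fold higher number from compound 2 to compound 3 (0.03 log units; within the scatter), so compound 2 and compound 3 cannot be told apart, and this place accepts a single bromine atom without a readable effect. The wider replacement, 4-bromophenyl in place of ethyl on the chain carbon bound to the amide-type nitrogen, gives a 1.6-fold lower number from compound 1 to compound 3 (0.21 log units; within the scatter), so compound 1 and compound 3 cannot be told apart either. No outside evidence bears on this result, and so nothing can be said about what lies behind it.

The compounds shown leave open how an amine or a carboxylic acid would read at this place on the ring. They also leave open whether a longer chain on the amide-type nitrogen would stay within the scatter of these three compounds.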